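The source may report more compounds than this note shows. Statements on the series, on what has been measured and on what is new or still open speak of the compounds shown alone.

Going by the values given here, in a functional assay on SK-BR-3 cells (Homo sapiens) for antiproliferative activity (on this read-out higher numbers stand for weaker inhibition and lower numbers for stronger inhibition), compound 2 `Cc1c(OC2CCN(C)CC2)ccc2cc(NC(=O)c3ccccc3)c(=O)oc12` gives 11500 nM, the higher of the two numbers measured so far and therefore the weaker result. The other measured molecule, compound 1 `Cc1c(OC2CCN(C)CC2)ccc2cc(NC(=O)c3ccc(O)c(CCC(C)C)c3)c(=O)oc12`, gives 600 nM, and this gap lies well beyond the usual scatter of repeat measurements.

The next molecule, compound 3 `C=CCc1cc(C(=O)Nc2cc3ccc(OC4CCN(C)CC4)c(C)c3oc2=O)ccc1O`, keeps the core of compound 2 and changes the group on the amide carbonyl. It carries 3-allyl-4-hydroxyphenyl in place of phenyl on a carbonyl carbon.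

Among the compounds with values here, no pair of measured compounds shows the effect of this exact change, so any forecast is uncertain. The best available guide is compound 1, whose value of 600 nM shows that molecules of this family can reach far lower numbers than compound 2 does. A move toward stronger inhibition therefore seems likely, beyond the scatter but smaller than the full gap between the two measured compounds.

The expected step is a 4.6-fold lower number from compound 2 to compound 3 (0.66 log units; beyond the scatter). For compound 3 the estimated value is 2500 nM, within an expected range of 800 nM to 8000 nM.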

Compound 3, half-maximal inhibitory concentration: 2430 nM
Beside the measured number, compound 3's estimate is 1.0-fold (0.01 log units) above it; the range from low to high includes it.
By their numbers in this assay, from the lowest: compound 1; then compound 3; then compound 2.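

In this assay, putting 3-allyl-4-hydroxyphenyl in place of phenyl on the carbonyl carbon gives a 4.7-fold lower number from compound 2 to compound 3 (0.68 log units; beyond the scatter), so this place on the amide accepts a larger, substituted aromatic ring, and here that swap brings a modest gain in strength. The comparison with compound 1 keeps the rest of the molecule and alters only the chain: vinyl in place of isobutyl on a saturated chain carbon bound to an aromatic carbon gives a 4.1-fold higher number from compound 1 to compound 3 (0.61 log units; beyond the scatter), which shows that the end of this chain also affects the number, with the allyl-bearing compound 3 the weaker of the two. Nothing available explains either step.

From the compounds shown here alone, compound 3 differs from compound 2 by the allyl group and the hydroxy group together, so how much of the step belongs to each remains open, and a phenyl carrying only one of them would be needed to separate the two. Going by these compounds alone, also open is how a chain longer than the one in compound 1, or an amine or a carboxylic acid at the end of that chain, would compare.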